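Alkyl extension on the compound 1 core: expectation for compound 4

A few compounds are considered here, and "the series" means these few. Any claim that something is new, unique, unknown or untested is made for them only; others in the source may bear on it.

Three members of the series have numbers in a functional assay on the whole organism for inhibition, with Rattus norvegicus as the target, at a dose of 1 mg/kg by the oral route; a higher number here means a stronger effect of the compound at the dose given, a lower number a weaker effect. Compound 1 `CCc1ccnc(C(=O)Nc2nn[nH]n2)c1` gives 32%, the lowest of the three. Compound 2 `Cc1cccc(C(=O)Nc2nn[nH]n2)n1` gives 40%, which lies within the scatter of compound 1. Compound 3 `Cc1cc(Cl)cc(C(=O)Nc2nn[nH]n2)n1` gives 66%, beyond the scatter above compound 1. Among the compounds with values here, the only single-point step among the measured compounds is a number 26 percentage points higher from compound 2 to compound 3 (beyond the scatter), a chloro in place of hydrogen on an aromatic carbon.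

Compound 4 `CC(C)c1ccnc(C(=O)Nc2nn[nH]n2)c1` is not yet measured. It differs from compound 1 by methyl in place of hydrogen on a saturated chain carbon bound to an aromatic carbon and a saturated chain carbon; cut one bond further out, the change reads ethyl to isopropyl. Within the data shown here, no measured step concerns a change of this kind: the one step in hand involves chloro on an aromatic carbon, not growth of a saturated chain, so it does not bear on the move from compound 1 to compound 4. With nothing in the series to point either way, the expected step is a number 3 percentage points higher from compound 1 to compound 4 (within the scatter), that is, none beyond the scatter. Compound 4 is therefore estimated at 35%, with a range from 15% to 55%.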

Compound 4, a percentage reported as inhibition, in the whole organism at one dose (the size of the read-out at that dose, not a potency): 36%
Beside the measured number, compound 4's estimate is 1 percentage points below it; the measured number falls inside the stated range.
By their numbers in this assay, from the lowest: compounds 1, 4 and 2 (each within the scatter of the next); then compound 3.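

In this assay, within the data shown here, ethyl to isopropyl on the core of compound 1 gives a number 4 percentage points higher from compound 1 to compound 4 (within the scatter), the first reading at this saturated chain carbon, so at the dose given the series does not separate these two alkyl groups. Among these compounds, the added methyl therefore stands apart from the chloro change, which gives a number 26 percentage points higher from compound 2 to compound 3 (beyond the scatter), still the only step beyond the scatter, although it concerns an aromatic carbon on a different pair and offers no direct comparison with the alkyl change. Nothing at hand on the compounds' properties or behaviour bears on this result, which therefore stays a plain observation at a single dose.

Open, on these data alone, is whether a tert-butyl group, a longer chain such as n-butyl, or a hydroxyl or amine on this saturated chain carbon would give a number beyond the scatter of compound 1. Also open, as far as these compounds go, is whether chloro on an aromatic carbon of the core of compound 1 would give a step like the one seen on the core of compound 2, and whether ethyl and isopropyl stay this close at other doses.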